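Replacing piperidin-4-yl with 5-nitrofuran-3-yl on the carbonyl

A few compounds are considered here, and "the series" means these few. Any claim that something is new, unique, unknown or untested is made for them only; others in the source may bear on it.

In a functional assay on SU-DHL-6 cells (Homo sapiens) for antiproliferative activity, read by MTT assay (on this read-out lower numbers stand for stronger inhibition and higher numbers for weaker inhibition), compound 1 (`COc1ncc(-c2ccc3ncnc(N[C@H]4CCCN(C(=O)C5CCOCC5)C4)c3c2)cc1C#N`) gives 150 nM and compound 2 (`COc1ncc(-c2ccc3ncnc(N[C@H]4CCCN(C(=O)C5CCN(C)CC5)C4)c3c2)cc1C#N`) gives 420 nM. Compound 3 (`COc1ncc(-c2ccc3ncnc(N[C@H]4CCCN(C(=O)C5CCNCC5)C4)c3c2)cc1C#N`) has the highest number of the three at 2440 nM and so the weakest inhibition. Compound 4 (`COc1ncc(-c2ccc3ncnc(N[C@H]4CCCN(C(=O)c5coc([N+](=O)[O-])c5)C4)c3c2)cc1C#N`) carries 5-nitrofuran-3-yl in place of piperidin-4-yl on a carbonyl carbon. Two measured steps change the group at this same place: a 16-fold higher number from compound 1 to compound 3 (1.21 log units; beyond the scatter) is large, and a 5.8-fold higher number from compound 2 to compound 3 (0.76 log units; beyond the scatter) is modest. Both times the piperidin-4-yl compound has the higher number. Going by the values given here, no measured compound carries the nitrofuran, so the transfer is uncertain. A step to a lower number is expected, estimated as a 7.0-fold lower number from compound 3 to compound 4 (0.84 log units; beyond the scatter). For compound 4 the estimate is 350 nM (expected range 90 nM to 1400 nM).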

Compound 4, half-maximal inhibitory concentration: 140 nM
For compound 4 the middle estimate is 2.5-fold (0.40 log units) above the measured one, and the stated range covers the measured number.
By their numbers in this assay, from the lowest: compounds 4 and 1 (each within the scatter of the next); then compound 2; then compound 3.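

In this assay the position on the carbonyl carbon accepts a five-membered aromatic ring without a basic amine: 5-nitrofuran-3-yl recovers activity against both piperidines (a 17-fold lower number from compound 3 to compound 4 (1.24 log units; beyond the scatter); a 3.0-fold lower number from compound 2 to compound 4 (0.48 log units; beyond the scatter)). Oxan-4-yl and 5-nitrofuran-3-yl are not separated here (a 1.1-fold lower number from compound 1 to compound 4 (0.03 log units; within the scatter)), so a saturated six-membered ring is not required in this set. Nothing available explains these steps.

Whether the nitro group contributes remains open, since unsubstituted furan-3-yl is not among the compounds shown. Phenyl and a nitrile-bearing furan also remain to be compared at this position.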